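Extending the amide chain of compound 1 toward an aryl group

The compounds below may be only part of what the source reports. "The series", "measured", "known", "first", "only" and "open" are said of these compounds alone.

Compound 1, `CCC(=O)Nc1sc2c(c1C#N)CCCC2`, is one of two analogues sharing a core tested in a functional assay on RKE cells for antagonist activity at Vasoactive intestinal polypeptide receptor 1 (Rattus norvegicus), read by HTRF and cAMP accumulation, with stated times of 10 min and 30 min (a higher number here means a weaker inhibitor, a lower number a stronger inhibitor), where compound 1 gives 12000 nM. This is the highest of the two numbers; its nearest neighbour is compound 2, `CC(C)C(=O)Nc1sc2c(c1C#N)CCCC2`, for which the same assay records 3400 nM, so that the step of a 3.5-fold lower number from compound 1 to compound 2 (0.55 log units; beyond the scatter) places compound 2 beyond the scatter. The unmeasured compound 3, `COc1ccc(CCC(=O)Nc2sc3c(c2C#N)CCCC3)cc1`, differs from compound 1 by 4-methoxyphenyl in place of hydrogen on a saturated chain carbon, two bonds along the chain from a carbonyl carbon. Among the measured compounds shown here, only the step from compound 1 to compound 2 bears on this change, and it shows that a larger group on the amide chain went with a modest improvement. Compound 3 carries a much larger group at a different place on that chain, so the outcome is uncertain, but an improvement of similar or greater size is expected. Compound 3 is therefore estimated at 3000 nM in this assay, within 800 nM to 12000 nM, corresponding to an expected step of a 4.0-fold lower number from compound 1 to compound 3 (0.60 log units; beyond the scatter).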

Compound 3, half-maximal inhibitory concentration: 410 nM
Compound 3: the middle estimate sits 7.3-fold (0.86 log units) above what was measured, and the stated range ends above it.
By their numbers in this assay, from the lowest: compound 3; then compound 2; then compound 1.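

In this assay the 4-methoxyphenyl group on a saturated chain carbon, two bonds along the chain from a carbonyl carbon, gives a 29-fold lower number from compound 1 to compound 3 (1.47 log units; beyond the scatter) and is printed as a large step, whereas the methyl group gave the modest 3.5-fold lower number from compound 1 to compound 2 (0.55 log units; beyond the scatter) at the chain carbon bound to the carbonyl carbon. The earlier pair spoke only for that carbon, and this result shows that the chain carbon further along also accepts a substituent, here one carrying an aromatic ring, with a much lower number. Nothing among the data shown accounts for the size of this step.

The compounds shown leave open whether the methoxy group contributes at all, as none of them carries a plain phenyl or a chlorophenyl in its place. They also leave open how a longer chain carrying the same ring would fare.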